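Shared-core series: chloro to nitro swap, cytotoxicity notes

The source may hold more compounds than are shown below. What is called first, only, known or untested is meant among the compounds shown, and "the series" means these compounds.

Compound 1 `CCOc1ccccc1Nc1nc(SCc2ccc(C(F)(F)F)cc2)nc2ccccc12`: > 50000 nM in a functional assay on MDA-MB-231 cells (Homo sapiens) for cytotoxicity, read by MTT assay, with a stated time of 72 h (a lower number here means a stronger inhibitor, a higher number a weaker inhibitor), a limit of the assay rather than a number.
Compound 2 `FC(F)(F)c1ccc(CSc2nc(Nc3ccc(Cl)cc3)c3ccccc3n2)cc1`: 15100 nM in this assay.

For the measured compounds named here, compound 2 holds the only number in this assay. Going by the values given here, the step of an at least 3.3-fold lower number from compound 1 to compound 2 (0.51 log units; beyond the scatter) is the only measured step, and the limit of > 50000 nM in this assay, at which 1 of the 2 values shown sits, shows that it rests on a limit. Compound 3 `O=[N+]([O-])c1ccc(Nc2nc(SCc3ccc(C(F)(F)F)cc3)nc3ccccc23)cc1` differs from compound 2 by nitro in place of chloro on an aromatic carbon. Among the compounds with values here, no measured step touches this pair of groups, so nothing here can be extrapolated. The expectation for compound 3 is a step of a 1.3-fold lower number from compound 2 to compound 3 (0.10 log units; within the scatter) within the scatter. Compound 3 is therefore estimated at 12000 nM, with a range of 4000 nM to 40000 nM, and a fair chance that only a limit is returned.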

Compound 3, half-maximal inhibitory concentration: 8670 nM
Compound 3: middle estimate off by 1.4-fold (0.14 log units), on the high side; measured number inside the range.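

Nitro in place of chloro on this aromatic carbon, para to a large group, gives a 1.7-fold lower number from compound 2 to compound 3 (0.24 log units; within the scatter), so in this assay the two groups are not told apart at this place. The wider change, 4-nitrophenyl in place of 2-ethoxyphenyl on the nitrogen, gives an at least 5.7-fold lower number from compound 1 to compound 3 (0.76 log units; beyond the scatter). That step has only one measured end, and compound 1 stands at a limit of the assay: the limit of > 50000 nM in this assay, at which 1 of the 3 values shown sits.

The compounds shown leave open whether an amine or a carboxylic acid on this aromatic carbon would move the number beyond the scatter from compound 2.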